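Chloro in place of hydrogen: expected effect on cell cytotoxicity

This account rests on a few compounds, and the source may have more. Where it says the series, first, only, none or still open, it means among the compounds named here.

Measured compounds:
compound 1 `COc1ccc(-c2nc(SCC(=O)c3sc(-c4ccc(Cl)cc4)nc3C)[nH]c(=O)c2C#N)cc1OC`: "not determined" (no result reported) in an ADME assay on HEK293 cells (Homo sapiens) for cytotoxicity, read by MTT assay, with a stated time of 48 h; on this read-out lower numbers stand for stronger inhibition and higher numbers for weaker inhibition
compound 2 `COc1cccc(-c2nc(SCC(=O)c3sc(-c4ccccc4)nc3C)[nH]c(=O)c2C#N)c1`: 90200 nM

Among the compounds with values here, compound 2 carries the only number known in this assay; compound 1 has no reported result, so the two cannot be compared. In this assay compound 2 gives 90200 nM, a weak effect on cell survival.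

Compound 3 `COc1cccc(-c2nc(SCC(=O)c3sc(-c4ccc(Cl)cc4)nc3C)[nH]c(=O)c2C#N)c1` differs from compound 2 in one place: chloro in place of hydrogen on an aromatic carbon. The change sits on an aromatic carbon of a six-membered aromatic ring of carbon only, para to a large group, and reads, cut one bond further out, phenyl to 4-chlorophenyl.

Within the data shown here, no measured pair shows what this change does here. The step from compound 2 to compound 3 is therefore expected to be small, a 1.3-fold lower number from compound 2 to compound 3 (0.11 log units; within the scatter), with no change beyond the usual scatter of this assay.

Compound 3 is expected to give about 70000 nM, within a range from 30000 nM to 160000 nM.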

Compound 3, half-maximal inhibitory concentration: 77900 nM
Compound 3: middle estimate off by 1.1-fold (0.05 log units), on the low side, within the range that was stated.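

In this assay, putting chloro in place of hydrogen on this aromatic carbon, para to a large group, gives a 1.2-fold lower number from compound 2 to compound 3 (0.06 log units; within the scatter). Within the data shown here, this is the first measured pair for the change, and it shows that going from phenyl to 4-chlorophenyl makes no difference here that can be told apart from the ordinary spread of repeated measurements. No independent measurement is available to explain this result.

One pair cannot show whether a different group at the same place, such as an amine or a carboxylic acid, would move the number beyond that spread. Among these compounds, it also remains open whether chloro would behave the same way on a compound with other changes elsewhere, since compound 1, the one other compound carrying it, has no reported result.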